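Demethylation at the aryl ether in the nitrile-bearing pyrazole series

This account rests on a few compounds, and the source may have more. Where it says the series, first, only, none or still open, it means among the compounds named here.

Three members of the series carry a measured number in a functional assay on Hs-578T cells (Homo sapiens) for inhibition, read by sulforhodamine B assay, with a stated time of 48 h; on this read-out lower numbers stand for stronger inhibition of growth and higher numbers for weaker inhibition of growth. Compound 1 `COc1cc(C)cc(-c2nn(CC#N)cc2-c2ccc(-c3cccc(C(C)=O)c3)nc2)c1` gives 1280 nM in this assay. Compound 2 `Cc1cc(O)cc(-c2nn(CC#N)cc2-c2ccnc(-c3ccc(Oc4ccccc4)cc3)c2)c1` gives 2020 nM in this assay. Compound 3 `COc1cc(C)cc(-c2nn(CC#N)cc2-c2ccnc(-c3ccc(N(C)C)cc3)c2)c1` gives 264 nM in this assay, the lowest of the three numbers, with the gap to compound 1 and the wider gap to compound 2 both beyond the scatter. For the measured compounds named here, compounds 1 and 2 each differ from compound 3 in more than one place, so no single step between measured compounds can be read off.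

Compound 4 `Cc1cc(O)cc(-c2nn(CC#N)cc2-c2ccnc(-c3ccc(N(C)C)cc3)c2)c1` differs from compound 3 by hydrogen in place of methyl on an oxygen on an aromatic ring, methoxy to hydroxy, 3-methoxy-5-methylphenyl to 3-hydroxy-5-methylphenyl. Going by the values given here, nothing among the measured compounds isolates this change; compound 2 carries the hydroxy form but with a different outer aryl. A modest step toward weaker inhibition is expected for compound 4, estimated as a 1.9-fold higher number from compound 3 to compound 4 (0.28 log units; within the scatter) in this assay. Compound 4 is therefore estimated at 500 nM, within 150 nM to 1600 nM.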

Compound 4, concentration for 50% growth inhibition: 2130 nM
For compound 4 the middle estimate is 4.3-fold (0.63 log units) below the measured one, outside the stated range (above it).
By their numbers in this assay, from the lowest: compound 3; then compounds 1, 2 and 4 (each within the scatter of the next).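

In this assay the methyl on this oxygen matters with the dimethylamino outer aryl: hydrogen in place of it gives an 8.1-fold higher number from compound 3 to compound 4 (0.91 log units; beyond the scatter) and thereby loses the lowest number in the set. With the hydroxy form held fixed, dimethylamino in place of phenoxy gives a 1.1-fold higher number from compound 2 to compound 4 (0.02 log units; within the scatter) and does not separate the two outer aryls. For the compounds shown here, the advantage of compound 3 is therefore tied to the methoxy in the one pair that isolates it, and it cannot be credited to the dimethylamino group alone.

On these data alone, whether ethoxy or an amine in place of the methoxy would hold the number of compound 3 stays open, as does the size of the same change with a phenoxy outer aryl. Nothing shown here gives a measured reason for the step.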